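Methyl at a Different Ring Carbon of Compound 1

This account rests on a few compounds, and the source may have more. Where it says the series, first, only, none or still open, it means among the compounds named here.

Compound 1 `COCCNC(=O)c1cnn(-c2cccc3cc(Cc4cccc(C(F)(F)F)c4)sc23)c1` gives 62 nM in a functional assay on CHO cells for agonist activity at G-protein coupled receptor 52 (Homo sapiens), read by AlphaScreen and cAMP accumulation, with a stated time of 30 min; a lower number here means that less compound is needed, a higher number that more compound is needed for the effect. Among the three compounds measured it holds the second highest number: nearest to it is compound 2 `O=C(NCCO)c1cnn(-c2cccc3cc(Cc4cccc(C(F)(F)F)c4)sc23)c1`, which gives 87 nM, and furthest is compound 3 `COCCNC(=O)c1cn(-c2cccc3cc(Cc4cccc(C(F)(F)F)c4)sc23)nc1C`, which gives 9.6 nM. The step of a 1.4-fold higher number from compound 1 to compound 2 (0.15 log units; within the scatter) stays within the scatter, whereas the step of a 6.5-fold lower number from compound 1 to compound 3 (0.81 log units; beyond the scatter) is a modest gain.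

Compound 4 `COCCNC(=O)c1cnn(-c2cccc3cc(Cc4cccc(C(F)(F)F)c4)sc23)c1C` differs from compound 1 by methyl in place of hydrogen on an aromatic carbon. The new methyl sits on an aromatic carbon of the five-membered aromatic ring with 2 nitrogen, next to the ring nitrogen, next to the ring atom that bears the (2-methoxyethyl)carbamoyl group and next to the ring atom that bears a large group. Of the measured steps, only a 6.5-fold lower number from compound 1 to compound 3 (0.81 log units; beyond the scatter) also adds a methyl to an aromatic carbon of this ring, though at another carbon, so it is the one that bears on the change. Whether a methyl at this other carbon acts alike is not shown by the data. Within the data shown here, the expectation is a step of a 2.1-fold lower number from compound 1 to compound 4 (0.32 log units; beyond the scatter) for compound 4, smaller than the one seen for compound 3 and with wide uncertainty. Compound 4 is estimated at 30 nM, within a range from 8 nM to 120 nM.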

Compound 4, half-maximal effective concentration: 62 nM
Beside the measured number, compound 4's estimate is 2.1-fold (0.32 log units) below it; low and high end bracket the measured number.
By their numbers in this assay, from the lowest: compound 3; then compounds 1, 4 and 2 (each within the scatter of the next).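

In this assay, the step of no change at the digits printed from compound 1 to compound 4 (within the scatter) shows that methyl in place of hydrogen on this aromatic carbon, next to the ring nitrogen and next to the ring atom that bears a (2-methoxyethyl)carbamoyl group, leaves the number as it stood in compound 1. Set against the step of a 6.5-fold lower number from compound 1 to compound 3 (0.81 log units; beyond the scatter), which lies beyond the scatter, this shows that among these compounds a methyl on the five-membered ring does not bring a gain wherever it is placed: the outcome depends on which ring carbon carries it. The data give no measurement that would account for this difference between the two ring carbons.

Going by these compounds, it remains open whether a larger or different group at this carbon, such as an ethyl, a chlorine, a hydroxymethyl or an amine, would also leave the number unchanged or would shift it in either direction. Also open, on these data alone, is whether the methyl at this carbon would give the same result on the alcohol side chain of compound 2, or together with the methyl that compound 3 carries at the other ring carbon.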